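Extending Compound 2 with a (2-hydroxyethyl)carbamoyl Group

The compounds below may be only part of what the source reports. "The series", "measured", "known", "first", "only" and "open" are said of these compounds alone.

Measured in a functional assay on MIA PaCa-2 cells (Homo sapiens) for inhibition, read by MTT assay, with a stated time of 4 days; a lower number here means a stronger inhibitor, a higher number a weaker inhibitor:
- compound 1 `COc1cc(NC(C)CCCNC(=O)NNC(=O)Nc2ccc(Cl)c(C(F)(F)F)c2)c2ncccc2c1`: 18000 nM
- compound 2 `COc1cc(NC(C)CCCNC(=O)NN)c2ncccc2c1`: >= 250000 nM

Only compound 1 has an exact number here. Compound 2 is reported as >= 250000 nM, which is a limit of the assay and not a number. Compound 3 `COc1cc(NC(C)CCCNC(=O)NNC(=O)NCCO)c2ncccc2c1` is built from compound 2 by one change: (2-hydroxyethyl)carbamoyl in place of hydrogen on an amine nitrogen. In words, (2-hydroxyethyl)carbamoyl stands in place of hydrogen on an amine nitrogen. Within the data shown here, no measured pair here differs in one place, so no direct precedent sizes this change. Among the measured compounds shown here, the only numerical guide is compound 1 at 18000 nM, so a modest gain in this assay is expected, with weak inhibition remaining. A result at the limit is still possible for compound 3. The expected change, an at least 2.5-fold lower number from compound 2 to compound 3 (0.39 log units; beyond the scatter), is only an estimate. The estimated value for compound 3 is 100000 nM, with an expected range of 30000 nM to 250000 nM.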

Compound 3, half-maximal inhibitory concentration: >= 250000 nM
Compound 3 was reported as a limit (the forecaster's own chance of this, stated with the estimate: 40%); middle value at least 2.5-fold (0.39 log units) away from the limit.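

In this assay, the step that adds (2-hydroxyethyl)carbamoyl to the amine nitrogen cannot be read, as compound 2 and compound 3 are both reported only as a limit: the limit of >= 250000 nM in this assay, at which 2 of the 3 values shown sit.

The new information comes from the other comparison: 2-hydroxyethyl in place of 4-chloro-3-(trifluoromethyl)phenyl on the amide-type nitrogen gives an at least 13-fold higher number from compound 1 to compound 3 (1.14 log units; beyond the scatter). The carbamoyl extension alone therefore does not bring a measurable value in this assay, and the group carried on that nitrogen makes a large difference.

As far as these compounds go, it remains open whether a plain phenyl, a 2-aminoethyl or a carboxymethyl group on that nitrogen would give a measurable value. It is also unclear whether the chlorine, the trifluoromethyl or the aromatic ring itself accounts for the difference.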